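The source may report more compounds than this note shows. Statements on the series, on what has been measured and on what is new or still open speak of the compounds shown alone.

Measured so far:
compound 1 `Fc1ccc(C2=NN(c3nc(-c4ccc(Br)cc4)cs3)C(c3cccs3)C2)cc1` gives 8280 nM
compound 2 `Fc1ccc(C2=NN(c3nc(-c4ccc(C(F)(F)F)cc4)cs3)C(c3cccs3)C2)cc1` gives 1330 nM

Within the data shown here, in a functional assay on MCF7 cells (Homo sapiens) for antiproliferative activity, read by MTT assay, with a stated time of 48 h (a lower number here means a stronger inhibitor, a higher number a weaker inhibitor), compound 1 has the higher of the two numbers, and its only neighbour in this set is compound 2, with 1330 nM. That pair shows a 6.2-fold lower number from compound 1 to compound 2 (0.79 log units; beyond the scatter). Compound 3 `Clc1ccc(C2=NN(c3nc(-c4ccc(Br)cc4)cs3)C(c3cccs3)C2)cc1` arises from compound 1 by chloro in place of fluoro on an aromatic carbon. Among the measured compounds shown here, the only measured step concerns a different group on a different ring, so nothing measured bears directly on this change. The step from compound 1 to compound 3 in this assay is therefore expected to be a 1.3-fold lower number from compound 1 to compound 3 (0.11 log units; within the scatter), nothing beyond the scatter. Compound 3 is estimated at 6500 nM, within 2000 nM to 20000 nM.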

Compound 3, half-maximal inhibitory concentration: 14700 nM
Beside the measured number, compound 3's estimate is 2.3-fold (0.35 log units) below it; the range from low to high includes it.
By their numbers in this assay, from the lowest: compound 2; then compounds 1 and 3 (each within the scatter of the next).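

Chloro in place of fluoro gives a 1.8-fold higher number from compound 1 to compound 3 (0.25 log units; within the scatter) in this assay and so, on this evidence, either halogen can sit on this ring with no difference that stands out from the scatter. Among these compounds, this is the first measured change on the 4-fluorophenyl group, as the earlier step concerned the other aromatic ring. Nothing available explains this result. 

Still open, from the compounds shown here alone, is how a methoxy group, an amine or a carboxylic acid would fare at this position. Going by these compounds, whether chloro would behave the same alongside the trifluoromethyl group of compound 2 also remains unknown.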